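A few compounds are considered here, and "the series" means these few. Any claim that something is new, unique, unknown or untested is made for them only; others in the source may bear on it.

Measured so far in a functional assay on A549 cells (Homo sapiens) for inhibition, read by MTT assay, with a stated time of 72 h; a lower number here means a stronger inhibitor, a higher number a weaker inhibitor:
compound 1 `Nc1nc2cc(-c3nn(CCCCC(=O)NO)c4ncnc(N)c34)ccc2o1`: > 100000 nM
compound 2 `Nc1ncnc2c1c(-c1cnc3[nH]ccc3c1)nn2CCC(=O)NO`: > 150000 nM
compound 3 `Nc1nc2cc(-c3nn(CCCCCC(=O)NO)c4ncnc(N)c34)ccc2o1`: > 100000 nM

Each of these three values is a limit of this assay, not a number. Compound 1 reaches only the limit (the limit of > 100000 nM in this assay, at which 2 of the 3 values shown sit). Compound 3 sits at that same limit. Compound 2 sits at a different limit, (the limit of > 150000 nM in this assay, at which 1 of the 3 values shown sits).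

Compound 3 differs from compound 1 by (hydroxycarbamoyl)methyl in place of hydroxycarbamoyl on a saturated chain carbon, four bonds along the chain from an aromatic nitrogen, and the step that the two limits leave unreadable from compound 1 to compound 3 cannot be sized, since both ends are limits. Compound 4 `Nc1ncnc2c1c(-c1cnc3[nH]ccc3c1)nn2CCCC(=O)NO` differs from compound 2 by (hydroxycarbamoyl)methyl in place of hydroxycarbamoyl on a saturated chain carbon, two bonds along the chain from an aromatic nitrogen, the same kind of change, though here the place is two bonds rather than four bonds along the chain from an aromatic nitrogen. How the core of compound 2 differs from that of compound 1 is not broken down here.

Since compound 2 in this assay gives > 150000 nM, compound 4 is expected to remain near that limit, an expected step that the limit leaves unreadable from compound 2 to compound 4. Compound 4 is estimated at 200000 nM, expected between 50000 nM and 1000000 nM.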

Compound 4, half-maximal inhibitory concentration: > 150000 nM
Compound 4: a limit, no number (the forecaster's own chance of this, stated with the estimate: 85%); the middle value does not contradict the limit.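

Among these compounds, compound 2 and compound 4 each give only a limit in this assay, not a number, so no step between them can be read. The compounds shown leave open whether chain length affects inhibition on either core.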